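The source may report more compounds than this note shows. Statements on the series, on what has been measured and on what is new or still open speak of the compounds shown alone.

Measured so far in a functional assay on the whole organism with Rattus norvegicus as the target, at a dose of 100 mg/kg; on this read-out lower numbers stand for less inhibition and higher numbers for more inhibition at the one dose given (going by the name of the read-out): compound 1 `CC/N=C(/NC#N)NCCCn1nc(-c2ccccc2)cc(C)c1=O` gives 23.5%. Compound 2 `CC/N=C(/NC#N)NCCCCn1nc(-c2ccccc2)cc(C)c1=O` gives 42.5%. Compound 3 `C/N=C(/NC#N)NCCCCCn1nc(-c2ccccc2)cc(C)c1=O` gives 33.8%.

Compound 3 stands second highest of the three numbers; compound 2 is nearest, within the scatter, and compound 1 furthest, beyond it. Compound 4 `C/N=C(/NC#N)NCCCCn1nc(-c2ccccc2)cc(C)c1=O` is not yet measured. Relative to compound 3 the change is a group of 7 heavy atoms (3 carbon, 4 nitrogen; no ring) in place of a group of 8 heavy atoms (4 carbon, 4 nitrogen; no ring), on a saturated chain carbon, four bonds along the chain from an aromatic nitrogen. Among the measured compounds shown here, the only measured step of comparable kind, a number 8.7 percentage points lower from compound 2 to compound 3 (within the scatter), stayed within the scatter; no other step bears on the question. A small step in this assay, not beyond the scatter in either direction, is therefore expected. Compound 4 is estimated at 38% (range 25% to 52%). This estimate means a step of a number 4.2 percentage points higher from compound 3 to compound 4 (within the scatter), expected to remain within the scatter.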

Compound 4, a percentage reported as inhibition, in the whole organism at one dose (the size of the read-out at that dose, not a potency): 68.6%
Estimate against measurement, compound 4: 30.6 percentage points below, and the stated range ends below it.
By their numbers in this assay, from the lowest: compound 1; then compounds 3 and 2 (each within the scatter of the next); then compound 4.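

The exchange on a saturated chain carbon, four bonds along the chain from an aromatic nitrogen, is not small: in this assay it gives a number 34.8 percentage points higher from compound 3 to compound 4 (beyond the scatter). Hydrogen in place of methyl on a saturated chain carbon bound to a double-bonded nitrogen gives a number 26.1 percentage points higher from compound 2 to compound 4 (beyond the scatter), so this place also moves the read-out. The exchange three bonds along the chain gives a number 45.1 percentage points higher from compound 1 to compound 4 (beyond the scatter), and the same change does not read alike on two cores: the same change on two cores in this assay, a number 8.7 percentage points lower (within the scatter) from compound 2 to compound 3 and a number 45.1 percentage points higher (beyond the scatter) from compound 1 to compound 4, 53.8 percentage points apart, beyond the scatter of two such steps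

Still open, on these data alone, is whether an amine, a carboxylic acid or a longer chain in place of the changing group would hold this level.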